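Halogen swap on the N-aryl ring of the shared core

The compounds below may be only part of what the source reports. "The series", "measured", "known", "first", "only" and "open" are said of these compounds alone.

Three compounds of the series have been run in a functional assay on Caco-2 cells (Homo sapiens) for antiproliferative activity, read by MTT assay, with a stated time of 72 h; a lower number here means a stronger inhibitor, a higher number a weaker inhibitor. Compound 1 `CC(=O)Oc1ccc(/C=C/C(=O)OCCSc2nc(-c3ccc(S(C)(=O)=O)cc3)n(-c3ccc(F)cc3)n2)cc1OC(C)=O` gives 12800 nM. Compound 2 `CC(=O)Oc1ccc(/C=C/C(=O)OCCSc2nc(-c3ccc(S(N)(=O)=O)cc3)n(-c3ccc(F)cc3)n2)cc1OC(C)=O` gives 11000 nM. Compound 3 `COc1cc(/C=C/C(=O)OCCSc2nc(-c3ccc(S(C)(=O)=O)cc3)n(-c3ccc(Br)cc3)n2)ccc1OC(C)=O` gives 12100 nM, the second highest of the three numbers; its distance to compound 1 and to compound 2 is within the scatter in both directions, so no order among the three can be read.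

Within the data shown here, the only single-point step recorded is a 1.2-fold lower number from compound 1 to compound 2 (0.07 log units; within the scatter), a change on the sulfonyl group, which does not touch the position altered here. Compound 4 `COc1cc(/C=C/C(=O)OCCSc2nc(-c3ccc(S(C)(=O)=O)cc3)n(-c3ccc(F)cc3)n2)ccc1OC(C)=O` differs from compound 3 by fluoro in place of bromo on an aromatic carbon. Compound 1 carries the same fluoro group, but differs from compound 3 in a second place as well, and its value and that of compound 3 lie within the scatter of each other. No measured step therefore bears directly on the change, and nothing shown argues for a shift beyond the scatter.

The expected step is a 1.0-fold lower number from compound 3 to compound 4 (0.00 log units; within the scatter), essentially flat. For compound 4 in this assay the estimate is 12000 nM, with a range from 6000 nM to 24000 nM.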

Compound 4, half-maximal inhibitory concentration: 10800 nM
Compound 4: middle estimate off by 1.1-fold (0.05 log units), on the high side; measured number inside the range.
By their numbers in this assay, from the lowest: compounds 4, 2, 3 and 1 (each within the scatter of the next).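

In this assay, among these compounds, the change from 4-bromophenyl to 4-fluorophenyl gives a 1.1-fold lower number from compound 3 to compound 4 (0.05 log units; within the scatter), the first direct reading of this halogen swap, and the position para to a large group shows no response beyond the scatter. Among the compounds shown here, the same compound also gives the first single-place reading at the oxygen on the aromatic ring, with a 1.2-fold lower number from compound 1 to compound 4 (0.07 log units; within the scatter) for methyl in place of acetyl, so neither of these two changes separates the compounds. No evidence on hand bears on these readings.

From the compounds shown here alone, both groups compared at the halogen position are halogens, so it remains open whether an amine or a carboxylic acid there would move the number beyond the scatter. A longer chain on the oxygen of the aromatic ring is equally untested among the compounds shown.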